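A few compounds are considered here, and "the series" means these few. Any claim that something is new, unique, unknown or untested is made for them only; others in the source may bear on it.

Measured so far in an ADME assay on the whole organism (Rattus norvegicus) for pharmacokinetics, read by HPLC, at a dose of 3 mg/kg by the oral route; a lower number here means less compound in the circulation, a higher number more compound in the circulation at the dose given:
- compound 1 `N#Cc1cc(C(=O)N2CS(=O)(=O)c3ccccc32)cc(Cl)c1O`: 3870 nM
- compound 2 `O=C(c1cc(Cl)c(O)c(C(F)(F)F)c1)N1CS(=O)(=O)c2ccccc21`: 16400 nM
- compound 3 `COc1cc(C(=O)N2CS(=O)(=O)c3ccccc32)cc(C(F)(F)F)c1O`: 10300 nM

Compound 3 gives 10300 nM, which lies within the usual scatter of compound 2 at 16400 nM. The number for compound 1, 3870 nM, is lower than both.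

Compound 4 `COc1cc(C(=O)N2CS(=O)(=O)c3ccccc32)cc(Cl)c1O` keeps the methoxy group of compound 3 and carries chloro in place of trifluoromethyl on an aromatic carbon, ortho to a hydroxy group: chloro in place of trifluoromethyl on an aromatic carbon.

Among the measured compounds shown here, no measured step makes this exact exchange, but two bear on it. With trifluoromethyl in place of cyano, the data show a 4.2-fold higher number from compound 1 to compound 2 (0.63 log units; beyond the scatter). For the measured compounds named here, this is the only measured step in which trifluoromethyl enters, and it points to some loss when that group leaves. With methoxy in place of chloro, the data show a 1.6-fold lower number from compound 2 to compound 3 (0.20 log units; within the scatter), so that exchange did not move this assay beyond the scatter. Compound 4 differs from compound 1 and from compound 2 at one group each, and its partner groups have not been measured together.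

A small fall is therefore expected, probably not clearly beyond the scatter. The expected step is a 1.7-fold lower number from compound 3 to compound 4 (0.23 log units; within the scatter).

Compound 4 is estimated at 6000 nM, with an expected range of 2500 nM to 14000 nM.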

Compound 4, maximal plasma concentration: 3000 nM
Compound 4: middle estimate off by 2.0-fold (0.30 log units), on the high side; the range from low to high includes it.
By their numbers in this assay, from the lowest: compounds 4 and 1 (each within the scatter of the next); then compounds 3 and 2 (each within the scatter of the next).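

In this assay, among the compounds shown here, the step of a 3.4-fold lower number from compound 3 to compound 4 (0.54 log units; beyond the scatter) shows that the group ortho to the hydroxy group matters with methoxy as its partner on the ring, and not only with chloro as its partner, the only setting the earlier step for trifluoromethyl could speak to. With chloro held fixed, methoxy in place of trifluoromethyl gives a 5.5-fold lower number from compound 2 to compound 4 (0.74 log units; beyond the scatter), whereas methoxy in place of cyano gives a 1.3-fold lower number from compound 1 to compound 4 (0.11 log units; within the scatter), so methoxy and cyano are not told apart in this assay, and among these four compounds the two carrying trifluoromethyl, compound 2 and compound 3, stand above the two without it, compound 1 and compound 4, with no compound going against that division. Nothing measured here explains why this exchange changes the amount of compound in the circulation.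

The compounds shown leave open whether the higher numbers belong to trifluoromethyl alone or would also come with a bromo group, a methyl group or an amine at this place. They also leave open whether the same division would hold if the hydroxy group were replaced, for example by an amine, or if the shared core were changed.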